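The compounds below may be only part of what the source reports. "The series", "measured", "known", "first", "only" and "open" are said of these compounds alone.

Of the compounds shown here, three have so far been tested in a functional assay on SNB-19 cells (Homo sapiens) for cytotoxicity, read by sulforhodamine B assay, with a stated time of 48 h, tested at 0.01 uM; a lower number here means a stronger effect, a higher number a weaker effect of the compound at the concentration tested. Compound 1 `COc1cc(-c2cc(/C=C/C(=O)c3ccc(Cl)c(Cl)c3)[nH]n2)cc(OC)c1OC` gives 100%, compound 2 `COc1ccc(-c2cc(/C=C/C(=O)c3ccc(N)cc3)[nH]n2)cc1OC` gives 96%, and compound 3 `COc1ccc(C(=O)/C=C/c2cc(-c3cc(OC)c(OC)c(OC)c3)n[nH]2)cc1` gives 97%. On these numbers compound 3 stands second highest of the three, with compound 2 nearest and compound 1 furthest, and both gaps lie within the scatter, so the three compounds cannot be told apart in this assay. Going by the values given here, the one measured step between compounds that differ in a single place is a number 3 percentage points lower from compound 1 to compound 3 (within the scatter).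

Compound 4 `COc1cc(-c2cc(/C=C/C(=O)c3ccc(F)c(F)c3)[nH]n2)cc(OC)c1OC` differs from compound 3 at that same place: 3,4-difluorophenyl in place of 4-methoxyphenyl on a carbonyl carbon. The step from compound 1 to compound 3 bears directly on this change, since it also swapped the group on the carbonyl carbon, and it stayed within the scatter. Nothing measured points to a different outcome for 3,4-difluorophenyl, so no step beyond the scatter is expected in this assay; the expected step is a number 1 percentage points higher from compound 3 to compound 4 (within the scatter). For compound 4 the estimated value in this assay is 98%, with a range from 90% to 105%.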

Compound 4, a percentage reported as activity, at one concentration (the size of the read-out at that concentration, not a potency): 89%
For compound 4 the middle estimate is 9 percentage points above the measured one, and the stated range ends above it.
By their numbers in this assay, from the lowest: compounds 4, 2, 3 and 1 (each within the scatter of the next, the first and the last beyond it).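

In this assay, the group on the carbonyl carbon now gives its first step beyond the scatter: 3,4-difluorophenyl in place of 3,4-dichlorophenyl gives a number 11 percentage points lower from compound 1 to compound 4 (beyond the scatter), a modest stronger effect at the concentration tested. The change from 4-methoxyphenyl to 3,4-difluorophenyl at the same place gives a number 8 percentage points lower from compound 3 to compound 4 (within the scatter), so that pair cannot be told apart, and the position shows only a slight sensitivity to the group it carries. Nothing available explains this difference.

The compounds shown leave open whether a phenyl carrying a nitrile, a trifluoromethyl or a carboxylic acid on this carbonyl carbon would move the read-out further. They also leave open how these compounds compare as a matter of potency, since one concentration gives no potency.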